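A few compounds are considered here, and "the series" means these few. Any claim that something is new, unique, unknown or untested is made for them only; others in the source may bear on it.

Working notes on the series. Going by the values given here, in an ADME assay on microsomes from liver (Homo sapiens) for metabolic stability, read by LC-MS, with a stated time of 40 min, tested at 0.5 uM (a lower number here means slower removal, a higher number faster removal of the compound), compound 1 (`CC(C)S(=O)(=O)c1cccc(NC(=O)c2cccnc2N2CCC3(CC2)CC3)c1`) gives 375 mL.min-1.g-1, the only actual number so far. Compound 2 (`CC(C)(O)CNc1ccc(C(=O)Nc2cccc(S(=O)(=O)C3CCCC3)n2)c(N2CCC3(CC2)CC3)c1`) reads > 399 mL.min-1.g-1, which is a limit of the assay. Compound 3 (`CC(C)(CO)Nc1ccc(C(=O)Nc2cccc(S(=O)(=O)NC3CCCC3)n2)c(N2CCC3(CC2)CC3)c1`) reads > 399 mL.min-1.g-1, also a limit. Among the compounds with values here, no step between measured compounds is available, so this assay offers no direct guide to the next change. Compound 4 (`O=C(Nc1cccc(S(=O)(=O)N2CCCC2)c1)c1cccnc1N1CCC2(CC1)CC2`) carries pyrrolidin-1-yl in place of isopropyl on a sulfonyl sulfur. Removal of compound 4 is expected to remain fast, given compound 1 at 375 mL.min-1.g-1. The estimated step of a 1.3-fold lower number from compound 1 to compound 4 (0.10 log units; within the scatter) is expected to stay within the usual scatter. For compound 4 the estimated value is 300 mL.min-1.g-1, with an expected range of 140 mL.min-1.g-1 to 399 mL.min-1.g-1.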

Compound 4, intrinsic clearance in microsomes: > 399 mL.min-1.g-1
Compound 4: a limit, no number; the forecaster's own chance of this, stated with the estimate: 30%; middle value at least 1.3-fold (0.12 log units) away from the limit.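

In this assay compound 4 reads > 399 mL.min-1.g-1, which is a limit of the assay and not a number. Pyrrolidin-1-yl in place of isopropyl on a sulfonyl sulfur gives the first direct comparison at this position, an at least 1.0-fold higher number from compound 1 to compound 4 (0.02 log units; that floor lies within the scatter), with no sign of slower removal. This comparison yields only a floor, and that floor rests on the assay limit: the limit of > 399 mL.min-1.g-1 in this assay, at which 3 of the 4 values shown sit.

As far as these compounds go, the size of the true step remains open. Also open, from the compounds shown here alone, is whether morpholin-4-yl or methyl on the sulfonyl sulfur would bring removal to a readable number.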